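This account rests on a few compounds, and the source may have more. Where it says the series, first, only, none or still open, it means among the compounds named here.

Compound 1 `N#Cc1cc(Cl)cc(Oc2cc(OCc3noc4nc(-n5ccnc5)ccc34)ccc2Cl)c1` gives 2.2 L/kg
Compound 2 `N#Cc1cc(Cl)cc(Oc2cc(OCc3n[nH]c4nc(N)ccc34)cc(F)c2Cl)c1` gives 3.5 L/kg

In an in vivo ADME assay on the whole organism (strain Sprague-Dawley) for pharmacokinetics, with Rattus norvegicus as the target, at a dose of 2 mg/kg by the intravenous route (a lower number here means that more of the compound stays in the plasma, a higher number that more of the compound sits outside the plasma), compound 1 stands at 2.2 L/kg and compound 2 at 3.5 L/kg so the two numbers lie within the scatter of each other. Compound 3 `CNc1ccc2c(COc3ccc(Cl)c(Oc4cc(Cl)cc(C#N)c4)c3)noc2n1` has not yet been measured. Among the measured compounds shown here, it carries methylamino in place of 1H-imidazol-1-yl on an aromatic carbon of the core of compound 1 methylamino in place of 1H-imidazol-1-yl on an aromatic carbon and no measured pair shows this change alone. No step beyond the scatter is expected in this assay in either direction. The estimated step of a 1.1-fold higher number from compound 1 to compound 3 (0.06 log units; within the scatter) stays within that scatter. For compound 3 the expected value is 2.5 L/kg with an estimated range from 1.2 L/kg to 5 L/kg when measured.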

Compound 3, volume of distribution: 2 L/kg
Compound 3: middle estimate off by 1.3-fold (0.10 log units), on the high side, within the range that was stated.
By their numbers in this assay, from the lowest: compounds 3, 1 and 2 (each within the scatter of the next).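

In this assay the exchange of 1H-imidazol-1-yl for methylamino gives a 1.1-fold lower number from compound 1 to compound 3 (0.04 log units; within the scatter) and so leaves the two compounds within the scatter of each other. At this aromatic carbon, next to the ring nitrogen, a five-membered aromatic ring can therefore give way to a group with no ring without a step beyond the scatter. Nothing measured explains this result.
On these data alone, what a carboxylic acid or a morpholine ring on this same carbon would give remains open.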